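Dropping the Nitro Group: From Compound 2 to Compound 3

The compounds below may be only part of what the source reports. "The series", "measured", "known", "first", "only" and "open" are said of these compounds alone.

Compound 1, `CC(=O)/C(=C/c1c(-c2ccccc2)[nH]c2ccccc12)C(=O)c1ccccc1`, gives 2000 nM in a functional assay on MT4 cells (Homo sapiens) for antiproliferative activity, read by MTT assay, with a stated time of 96 h; on this read-out higher numbers stand for an effect only at larger amounts of compound and lower numbers for an effect already at smaller amounts.
Compound 2, `CCOC(=O)/C(=C/c1c(-c2ccccc2)[nH]c2ccccc12)C(=O)c1ccc([N+](=O)[O-])cc1`, gives 1500 nM in this assay.

On these two numbers compound 2 and compound 1 lie within the scatter of each other, so neither stands apart. Compound 3, `CCOC(=O)/C(=C/c1c(-c2ccccc2)[nH]c2ccccc12)C(=O)c1ccccc1`, differs from compound 2 by hydrogen in place of nitro on an aromatic carbon. Within the data shown here, no measured pair shows this change, so the step in this assay is expected to be small, with no clear direction beyond the scatter. Compound 3 is therefore estimated at 2500 nM, between 900 nM and 7000 nM, an expected step of a 1.7-fold higher number from compound 2 to compound 3 (0.22 log units; within the scatter).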

Compound 3, half-maximal effective concentration: 7000 nM
Compound 3: the middle estimate sits 2.8-fold (0.45 log units) below what was measured; the measured number falls inside the stated range.
By their numbers in this assay, from the lowest: compounds 2 and 1 (each within the scatter of the next); then compound 3.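

In this assay, among these compounds, hydrogen in place of nitro on an aromatic carbon, para to a large group, gives a 4.7-fold higher number from compound 2 to compound 3 (0.67 log units; beyond the scatter), the first single change to reach beyond the scatter. Ethoxy in place of methyl on a carbonyl carbon gives a 3.5-fold higher number from compound 1 to compound 3 (0.54 log units; beyond the scatter), so compound 3 stands apart from each earlier compound through one change. Nothing measured here gives a reason for either step. As far as these compounds go, whether an amine or a carboxylic acid on that aromatic carbon would match nitro remains open. So does the effect of a longer chain in place of ethoxy.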